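A Saturated Ring Replaces the Furan: Solubility Expected Higher

The source may hold more compounds than are shown below. What is called first, only, known or untested is meant among the compounds shown, and "the series" means these compounds.

Compound 1 `Cc1ccoc1C(=O)N1CCC(NC(=O)Nc2ccc(C(F)(F)F)cc2)CC1`: 0.8 ug/mL
Compound 2 `Cc1ccoc1C(=O)N1CCC(NC(=O)Nc2ccc(OC(F)(F)F)cc2)CC1`: 0.92 ug/mL
Compound 3 `O=C(Nc1ccc(OC(F)(F)F)c(F)c1)NC1CCN(C(=O)N2CCOCC2)CC1`: 96 ug/mL

All three were measured in a physicochemical assay for solubility, read by mass spectrometry, in phosphate buffer, with a stated time of 24 h, at pH 7.4; a higher number here means a more soluble compound, a lower number a less soluble compound. Compound 1 stands at the lowest of the three numbers. Compound 2 is nearest to it: the step of a 1.2-fold higher number from compound 1 to compound 2 (0.06 log units; within the scatter) lies within the scatter, so these two cannot be told apart. Compound 3 is furthest, with a much higher number, but it differs from compound 1 in several places at once, so no single step can be read from it.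

Compound 4 `O=C(Nc1ccc(C(F)(F)F)cc1)NC1CCN(C(=O)C2CCOCC2)CC1` is not yet measured. Its change from compound 1 is oxan-4-yl in place of 3-methylfuran-2-yl on a carbonyl carbon. Going by the values given here, the only measured step, between compound 1 and compound 2, concerns the other end of the molecule and does not bear on this change. Compound 3, which also carries a six-membered non-aromatic ring with one hetero atom on the carbonyl carbon, does give the highest number seen, though its aromatic part differs as well. On that basis the number for compound 4 is expected to rise, by an estimated 6.3-fold higher number from compound 1 to compound 4 (0.80 log units; beyond the scatter). The estimated value for compound 4 in this assay is 5 ug/mL, with a range from 1.5 ug/mL to 20 ug/mL.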

Compound 4, solubility: 17.6 ug/mL
For compound 4 the middle estimate is 3.5-fold (0.55 log units) below the measured one, within the range that was stated.
By their numbers in this assay, from the lowest: compounds 1 and 2 (each within the scatter of the next); then compound 4; then compound 3.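

Going by these compounds alone, compound 1 and compound 4 differ only in the group on the carbonyl carbon, so this is the first reading of that place on its own: in this assay, oxan-4-yl in place of 3-methylfuran-2-yl gives a 22-fold higher number from compound 1 to compound 4 (1.34 log units; beyond the scatter) with the rest of the molecule unchanged. The two groups have the same counts of heavy atoms, hydrogen-bond donors and hydrogen-bond acceptors, yet one is a five-membered aromatic ring and the other a six-membered non-aromatic ring. No measurement shown here explains the size of this step.

From the compounds shown here alone, it remains open whether an open chain or a ring carrying an amine or a carboxylic acid would behave like oxan-4-yl on this carbonyl carbon. Also open, going by these compounds, is whether the same exchange would give a step of similar size with the trifluoromethoxy group of compound 2 .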